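Dithiocarbamate side-chain variation on the shared core

The compounds below may be only part of what the source reports. "The series", "measured", "known", "first", "only" and "open" are said of these compounds alone.

Two measured compounds anchor the series. Compound 1 `Cc1ccc2c(=O)c(CSC(=S)N(C(C)C)C(C)C)coc2c1` gives 1400 nM in a functional assay on HeLa cells (Homo sapiens) for antiproliferative activity, read by MTT assay, with a stated time of 72 h; on this read-out lower numbers stand for stronger inhibition and higher numbers for weaker inhibition. Compound 2 `CCOC(=O)c1cc(=O)c2cc(CSC(=S)N(C)c3ccccc3)ccc2o1` gives 18100 nM in this assay, the highest of the two numbers; compound 1 sits well below it, beyond the scatter. Compound 3 `CCOC(=O)c1cc(=O)c2cc(CSC(=S)N3CCOCC3)ccc2o1` is not yet measured and differs from compound 2 in one place: morpholin-4-yl in place of methyl(phenyl)amino on a thiocarbonyl carbon. Going by the values given here, no pair of measured compounds covers a morpholin-4-yl against methyl(phenyl)amino on a thiocarbonyl carbon, so the size of this change in this assay cannot be read from the present numbers; compound 1 differs from compound 2 in several places at once and gives no clean step. The expected step in this assay is a 1.2-fold lower number from compound 2 to compound 3 (0.08 log units; within the scatter), with no clear direction beyond the scatter. Compound 3 is accordingly estimated at 15000 nM in this assay, within a range from 5000 nM to 45000 nM.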

Compound 3, half-maximal inhibitory concentration: > 25000 nM
Compound 3 ended at the assay's limit; the forecaster's own chance of this, stated with the estimate: 15%; middle value at least 1.6-fold (0.22 log units) from the limit.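

Going by these compounds alone, this is the first single-place step on the thiocarbonyl carbon of the series: morpholin-4-yl in place of methyl(phenyl)amino gives an at least 1.3-fold higher number from compound 2 to compound 3 (0.14 log units; that floor lies within the scatter) in this assay. For compound 3, > 25000 nM is a limit of the assay and not a number, so the exchange shows no lowering of the number, while the true size of the step stays unfixed. The limit also bears on how far this series can be read in this assay: the limit of > 25000 nM in this assay, at which 1 of the 3 values shown sits.

Open, on these data alone, is whether a piperidin-1-yl ring, a piperazine ring with a free amine or a diethylamino group on the same thiocarbonyl carbon would give a number within the range of the assay. Also open, as far as these compounds go, is how the ethyl ester on the shared core contributes, for instance against a free carboxylic acid.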